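The source may report more compounds than this note shows. Statements on the series, on what has been measured and on what is new or still open speak of the compounds shown alone.

Compound 1 `O=c1c(CSC(=S)N2CCOCC2)coc2cc(Cl)ccc12` and compound 2 `O=c1c(CSC(=S)N2CCOCC2)coc2ccccc12` share a core and differ in one place. In a functional assay on LM7 cells (Homo sapiens) for antiproliferative activity, read by MTT assay, with a stated time of 72 h (a higher number here means a weaker inhibitor, a lower number a stronger inhibitor), compound 1 gives 6200 nM, and compound 2 gives 12000 nM. Going by the values given here, the only step between them, a 1.9-fold higher number from compound 1 to compound 2 (0.29 log units; within the scatter), exchanges a chloro on an aromatic carbon for a hydrogen. Compound 2 thus holds the highest of the two numbers, and its nearest neighbour, compound 1, is within the scatter of it.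

Compound 3 `Cc1ccc2c(=O)c(CSC(=S)N3CCOCC3)coc2c1` is not yet measured. It differs from compound 2 by methyl in place of hydrogen on an aromatic carbon. Among the compounds with values here, the only step that bears on this change is the one from compound 1 to compound 2, which stayed within the scatter, so no change beyond the scatter is expected in this assay here either. The step from compound 2 to compound 3 is therefore estimated at a 1.3-fold lower number from compound 2 to compound 3 (0.12 log units; within the scatter). For compound 3 the expected value in this assay is 9000 nM, with a range from 3500 nM to 25000 nM.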

Compound 3, half-maximal inhibitory concentration: 14300 nM
Compound 3: middle estimate off by 1.6-fold (0.20 log units), on the low side; measured number inside the range.
By their numbers in this assay, from the lowest: compounds 1, 2 and 3 (each within the scatter of the next, the first and the last beyond it).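

With methyl in place of hydrogen on this aromatic carbon, this assay shows a 1.2-fold higher number from compound 2 to compound 3 (0.08 log units; within the scatter) and so does not separate these two groups at this position. Going by these compounds alone, the comparison of methyl with chloro at the same place gives a 2.3-fold higher number from compound 1 to compound 3 (0.36 log units; beyond the scatter) and is the first step here beyond the scatter, though it is modest and compound 2, carrying hydrogen, lies within the scatter of both compound 1 and compound 3. No measurement is available that could explain this gap between chloro and methyl.

The compounds shown leave open how a methoxy, an amine or a carboxylic acid on this aromatic carbon would read, and whether a longer chain such as ethyl would read like methyl. On these data alone, all three also share the rest of the core, so whether the gap between chloro and methyl holds with a change elsewhere remains open too.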